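A few compounds are considered here, and "the series" means these few. Any claim that something is new, unique, unknown or untested is made for them only; others in the source may bear on it.

Measured so far in a functional assay on MCF7 cells (Homo sapiens) for cytotoxicity, read by MTT assay, with a stated time of 48 h; on this read-out higher numbers stand for weaker inhibition and lower numbers for stronger inhibition:
compound 1 `COc1cc(C#N)ccc1OCc1nnc(-c2ccc(F)cc2)o1` — 10300 nM
compound 2 `COc1cc(C#N)ccc1OCc1nnc(-c2ccc(Cl)cc2)o1` — 21500 nM
compound 3 `N#Cc1ccc(OCc2nnc(-c3ccc(F)cc3)o2)cc1F` — 20500 nM

Compound 1 and compound 2 share one core and differ in a single place, (chloro in place of fluoro on an aromatic carbon). In this assay this change gave a 2.1-fold higher number from compound 1 to compound 2 (0.32 log units; beyond the scatter). Compound 3 is built on a different core; how the core of compound 3 differs from the core of compound 1 is not broken down here. The value of compound 3 lies within the scatter of the value of compound 2, and also within the scatter of the value of compound 1, so nothing can be said about order among these three pairs beyond the one step already named.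

Compound 4 `N#Cc1ccc(OCc2nnc(-c3ccc(Cl)cc3)o2)cc1F` has not yet been measured in this assay. It stands to compound 3 as compound 2 stands to compound 1: the change is chloro in place of fluoro on an aromatic carbon, and the place is described in the same words in both cases, so it is the same change carried onto the core of compound 3. The expectation for compound 4 is a step of the same direction and similar size, a 2.0-fold higher number from compound 3 to compound 4 (0.29 log units; within the scatter), because the same change earlier produced a 2.1-fold higher number from compound 1 to compound 2 (0.32 log units; beyond the scatter). Compound 4 is therefore expected to give about 40000 nM in this assay, most likely between 20000 nM and 85000 nM.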

Compound 4, half-maximal inhibitory concentration: 48300 nM
Beside the measured number, compound 4's estimate is 1.2-fold (0.08 log units) below it, within the range that was stated.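

In this assay, chloro in place of fluoro on the second core gave a 2.4-fold higher number from compound 3 to compound 4 (0.37 log units; beyond the scatter), and this step agrees with the one seen earlier on the other core: the same change on two cores in this assay, a 2.1-fold higher number (0.32 log units; beyond the scatter) from compound 1 to compound 2 and a 2.4-fold higher number (0.37 log units; beyond the scatter) from compound 3 to compound 4, 1.1-fold (0.05 log units) apart, within the scatter of two such steps. Across these two cores, then, the change from 4-fluorophenyl to 4-chlorophenyl carried over in direction and in size, with the chloro member giving the higher number, and so the weaker inhibition, on both. This rests on two matched pairs in a single assay, so it does not show why the two steps agree, nor that the same step would appear on any further core or at another place in these molecules.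

The compounds shown leave open what other groups would do at this place, such as bromo, an amine or a carboxylic acid in place of the halogen. They also leave open whether the step between chloro and fluoro would look the same on cells other than those of this assay.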